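Chloro in Place of Methyl on Compound 3

The compounds below may be only part of what the source reports. "The series", "measured", "known", "first", "only" and "open" are said of these compounds alone.

In a functional assay on the whole organism (strain Wistar) with Rattus norvegicus as the target, with a stated time of 15 days, at a dose of 100 mg/kg by the oral route (on this read-out higher numbers stand for a stronger effect at the one dose given and lower numbers for a weaker effect), compound 3 `Cc1ccc(-c2nnc(SCCOc3ccc(/C=C4\SC(=O)NC4=O)cc3)[nH]2)cc1` gives 54%. Compound 2 `O=C1NC(=O)/C(=C/c2ccc(OCc3csc(-c4ccccc4)n3)cc2)S1` gives 54%, so the two stand level, with no difference at the digits shown. Compound 1 `Cc1nc(COc2ccc(/C=C3\SC(=O)NC3=O)cc2)cs1` gives 38.9%, a number below both beyond the usual scatter. Among the measured compounds shown here, the only measured step, a number 15.1 percentage points higher from compound 1 to compound 2 (beyond the scatter), concerns a different change at a different place.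

Compound 4 `O=C1NC(=O)/C(=C/c2ccc(OCCSc3nnc(-c4ccc(Cl)cc4)[nH]3)cc2)S1` differs from compound 3 by chloro in place of methyl on an aromatic carbon. For the measured compounds named here, no measured step bears on this exchange of one small aromatic substituent for another, so nothing in the data supports a shift either way. The step from compound 3 to compound 4 is therefore expected to be no change at the digits printed from compound 3 to compound 4 (within the scatter), within the scatter. Compound 4 is estimated at 54%, with a range from 38% to 68%.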

Compound 4, a percentage reported as activity, at one dose (the size of the read-out at that dose, not a potency): 41.6%
Compound 4: the middle estimate sits 12.4 percentage points above what was measured; the range from low to high includes it.
By their numbers in this assay, from the lowest: compounds 1 and 4 (each within the scatter of the next); then compounds 2 and 3 (each within the scatter of the next).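

In this assay the exchange of 4-methylphenyl for 4-chlorophenyl comes with a number 12.4 percentage points lower from compound 3 to compound 4 (beyond the scatter) and so shows that this place, para to a large group, is not indifferent to its substituent. Methyl and chloro each bring 1 heavy atom, so a swap of one atom here is enough to move the read-out beyond the scatter. Nothing measured here explains the difference.

From the compounds shown here alone, whether a methoxy group or an amine at this place would score nearer compound 3 or compound 4 remains open. So does whether the same exchange would have a similar effect on another compound.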